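A few compounds are considered here, and "the series" means these few. Any claim that something is new, unique, unknown or untested is made for them only; others in the source may bear on it.

Measured in an assay on isolated protein for inhibition of protein deacetylase HDAC6 (Homo sapiens), read by fluorescence, with stated times of 10 min and 2 h; on this read-out lower numbers stand for stronger inhibition and higher numbers for weaker inhibition:
compound 1 `CN1CC(=O)N(Cc2ccc(C(=O)NO)cc2)C1=O` gives 119 nM
compound 2 `CC(C)(C)c1ccc(CN2CC(=O)N(Cc3ccc(C(=O)NO)cc3)C2=O)cc1` gives 40.7 nM
compound 3 `CC(C)CC1C(=O)N(Cc2ccc(C(=O)NO)cc2)C(=O)N1C` gives 251 nM

Compound 3 stands at the highest number of the three in this assay. Among the compounds with values here, the one step that reaches it, a 2.1-fold higher number from compound 1 to compound 3 (0.32 log units; beyond the scatter), is a modest rise beyond the scatter, and compound 2 stands furthest below it.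

Compound 4 `CC(C)CC1C(=O)N(Cc2ccc(C(=O)NO)cc2)C(=O)N1Cc1ccccc1` is compound 3 with phenyl in place of hydrogen on a saturated chain carbon bound to an amide-type nitrogen in a ring. Within the data shown here, no measured pair repeats this exact change. The nearest comparison is compound 1 against compound 2, where a larger arylmethyl group on the other ring nitrogen goes with a lower number in this assay; that pair is not a single-step comparison and its nitrogen differs from the one changed here, so it guides direction more than size. The step from compound 1 to compound 3 shows that a substituent elsewhere on the core can also raise the number, so neither direction is excluded.

On balance a move toward lower numbers, of modest size, is expected for compound 4: its step from compound 3 is estimated as a 2.3-fold lower number from compound 3 to compound 4 (0.36 log units; beyond the scatter). Compound 4 is therefore expected to give about 110 nM in this assay, with a plausible range from 40 nM to 300 nM.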

Compound 4, half-maximal inhibitory concentration: 129 nM
Compound 4: the middle estimate sits 1.2-fold (0.07 log units) below what was measured, within the range that was stated.
By their numbers in this assay, from the lowest: compound 2; then compounds 1, 4 and 3 (each within the scatter of the next, the first and the last beyond it).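

In this assay the change from methyl to benzyl, phenyl in place of hydrogen on a saturated chain carbon bound to an amide-type nitrogen in a ring, gives a 1.9-fold lower number from compound 3 to compound 4 (0.29 log units; within the scatter) and so cannot be told apart from repeat measurement. The earlier compounds shown here showed only that isobutyl in place of hydrogen on a saturated ring carbon gives a 2.1-fold higher number from compound 1 to compound 3 (0.32 log units; beyond the scatter); the present pair adds that, with isobutyl in place, this position carries a phenyl group with no change in the number beyond the scatter. No measurement here bears on why the number behaves this way at this position.

The compounds shown leave open whether a different group on this carbon, such as a carboxylic acid, an amine or a longer chain ending in phenyl, would move the number beyond the scatter. They also leave open whether the change from methyl to benzyl would give a similar step on the core of compound 1, which has no isobutyl group.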